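Swapping the outer aryl group on a bile acid receptor ligand

The source may hold more compounds than are shown below. What is called first, only, known or untested is meant among the compounds shown, and "the series" means these compounds.

Compound 2 `COC(=O)/C=C/c1cccc(N(Cc2ccc(/C=C/c3cccc(F)c3)cc2)C(=O)NC(C)C)c1` in an assay on isolated protein with Bile acid receptor (Homo sapiens) as the target (on this read-out higher numbers stand for an effect only at larger amounts of compound and lower numbers for an effect already at smaller amounts), gives 467 nM, while compound 1 `COC(=O)/C=C/c1cccc(N(Cc2ccc(-c3ccc(C)cc3)cc2)C(=O)NC(C)C)c1` gives 449 nM, so the two sit within the scatter of each other, as the step of a 1.0-fold higher number from compound 1 to compound 2 (0.02 log units; within the scatter) shows. Compound 3 `COC(=O)/C=C/c1cccc(N(Cc2ccc(-c3c(OC)cccc3OC)cc2)C(=O)NC(C)C)c1` differs from compound 2 only by 2,6-dimethoxyphenyl in place of 2-(3-fluorophenyl)ethenyl on an aromatic carbon. Going by the values given here, the one measured step bearing on this position is the small one from compound 1 to compound 2, so a change within the scatter or only slightly beyond it is expected in this assay, giving an estimated step of a 1.3-fold higher number from compound 2 to compound 3 (0.11 log units; within the scatter). Compound 3 is therefore estimated at 600 nM, within a range from 250 nM to 1500 nM.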

Compound 3, half-maximal effective concentration: 561 nM
Estimate against measurement, compound 3: 1.1-fold (0.03 log units) above; the measured number falls inside the stated range.
By their numbers in this assay, from the lowest: compounds 1, 2 and 3 (each within the scatter of the next).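

In this assay this position accepts a third outer group with no change beyond the scatter, as shown by a 1.2-fold higher number from compound 2 to compound 3 (0.08 log units; within the scatter) and by a 1.2-fold higher number from compound 1 to compound 3 (0.10 log units; within the scatter) in the same way. The 2,6-dimethoxyphenyl group has 2 hydrogen-bond acceptors and no double bond outside its ring, whereas 2-(3-fluorophenyl)ethenyl has no acceptors and one such double bond, yet the numbers stay level. No measured evidence explains this.

Still open, on these data alone, is whether an outer ring carrying an amine or a carboxylic acid would shift the number beyond the scatter. The same question applies to a simple alkyl chain in place of the ring.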